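The source may hold more compounds than are shown below. What is called first, only, known or untested is meant among the compounds shown, and "the series" means these compounds.

Compound 1 `COc1cc[nH]c1/C=C1\C(=O)Nc2ccc([N+](=O)[O-])c(N[C@H]3CC[C@H](O)CC3)c21` gives 8550 nM in a functional assay on MDA-MB-435 cells (Homo sapiens) for antiproliferative activity, read by MTT assay, with a stated time of 5 days; a lower number here means a stronger inhibitor, a higher number a weaker inhibitor. Compound 2 `COc1cc[nH]c1/C=C1\C(=O)Nc2ccc([N+](=O)[O-])c(N3CC[C@@H](N)C3)c21` reaches only the assay limit, < 10 nM. Compound 3 `COc1cc[nH]c1/C=C1\C(=O)Nc2ccc([N+](=O)[O-])c(N[C@H]3CC[C@H](N)C3)c21` gives 61 nM.

Compound 3 therefore holds the lowest of the two plain numbers, with a 140-fold lower number from compound 1 to compound 3 (2.15 log units; beyond the scatter). Compound 4 `COc1cc[nH]c1/C=C1\C(=O)Nc2ccc([N+](=O)[O-])c(N3CCC(N)CC3)c21` differs from it by 4-aminopiperidin-1-yl in place of (3-aminocyclopentyl)amino on an aromatic carbon. Among the measured compounds shown here, two measured steps bear on this: an at least 850-fold lower number from compound 1 to compound 2 (2.93 log units; beyond the scatter), where a ring joined through its own nitrogen replaced a ring joined through an outside amine, and an at least 6.1-fold higher number from compound 2 to compound 3 (0.78 log units; beyond the scatter), the reverse kind of change. Because compound 2 sits at the limit (the limit of < 10 nM in this assay, at which 1 of the 3 values shown sits), the size of the gain is uncertain, but a lower number is expected for compound 4, roughly a 4.1-fold lower number from compound 3 to compound 4 (0.61 log units; beyond the scatter). Compound 4 is estimated at 15 nM, between 5 nM and 60 nM.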

Compound 4, half-maximal inhibitory concentration: < 10 nM
Compound 4: a limit, no number; the forecaster's own chance of this, stated with the estimate: 35%; middle value at least 1.5-fold (0.17 log units) from the limit.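

With the same atoms joined differently, 4-aminopiperidin-1-yl on this aromatic carbon gives an at least 6.1-fold lower number from compound 3 to compound 4 (0.78 log units; beyond the scatter), so 3-aminopyrrolidin-1-yl is no longer the only ring joined through its own nitrogen with such a low value. Replacing (4-hydroxycyclohexyl)amino with this ring gives an at least 850-fold lower number from compound 1 to compound 4 (2.93 log units; beyond the scatter). Compound 2 and compound 4 each stand at a limit, so the step between them cannot be read: the limit of < 10 nM in this assay, at which 2 of the 4 values shown sit.

On these data alone, how much the ring's amine contributes stays open. A 4-hydroxypiperidin-1-yl group here would separate the amine's part from that of the ring's attachment through nitrogen.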